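Two Aryl Groups Beyond the Limit, a Third to Come

A few compounds are considered here, and "the series" means these few. Any claim that something is new, unique, unknown or untested is made for them only; others in the source may bear on it.

The shared core carries a five-membered aromatic ring with three nitrogens, and on one of those nitrogens sits an aryl group that is the only thing varied here. Compound 1 `Cc1ccccc1-n1nncc1CN1C(=O)C2(C(C#N)=C(N)Oc3c(N)cc4nc5ccccc5nc4c32)c2ccccc21` has a 2-methylphenyl group there. In a functional assay on HepG2 cells (Homo sapiens) for antiproliferative activity, read by MTT assay, with a stated time of 48 h (on this read-out lower numbers stand for stronger inhibition and higher numbers for weaker inhibition), compound 1 gives > 50000 nM, which is a limit of the assay and not a number. Compound 2 `CCOc1ccc(-n2nncc2CN2C(=O)C3(C(C#N)=C(N)Oc4c(N)cc5nc6ccccc6nc5c43)c3ccccc32)cc1` carries a 4-ethoxyphenyl group in the same place. In this assay compound 2 gives > 50000 nM, again a limit rather than a measured value. The step that the two limits leave unreadable from compound 1 to compound 2 therefore cannot be read, because both values sit at the limit of > 50000 nM in this assay, at which 2 of the 2 values shown sit.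

Compound 3 `CCc1cccc(C)c1-n1nncc1CN1C(=O)C2(C(C#N)=C(N)Oc3c(N)cc4nc5ccccc5nc4c32)c2ccccc21` differs from compound 2 by 2-ethyl-6-methylphenyl in place of 4-ethoxyphenyl on an aromatic nitrogen. Among the compounds with values here, no measured step shows how any aryl variation on this nitrogen changes the read-out, since the only step available is unreadable. The expectation for compound 3 is therefore simply that it behaves as the two measured compounds do. Compound 3 is expected to give 60000 nM, with a likely span from 20000 nM to 200000 nM. The expected step is a step that the limit leaves unreadable from compound 2 to compound 3, and most likely the assay will again report only a limit.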

Compound 3, half-maximal inhibitory concentration: > 50000 nM
Compound 3 gave a limit, no number; the forecaster's own chance of this, stated with the estimate: 80%; the middle value lies beyond the limit too.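

In this assay compound 3 gives > 50000 nM, a limit of the assay and not a number. Compound 1 and compound 2 sit at a limit too, so no step among these three compounds can be read: the limit of > 50000 nM in this assay, at which 3 of the 3 values shown sit.

The compounds shown leave open whether any aryl group on this nitrogen can give a measurable value in this read-out.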